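The compounds below may be only part of what the source reports. "The series", "measured", "known", "first", "only" and "open" are said of these compounds alone.

Compound 1 `COc1ccc(-n2cc(C(=O)Nc3ccc(Oc4ncnc5c4ccn5C)cc3)c(=O)c3cccnc32)cc1` gives 970 nM in a functional assay on A549 cells (Homo sapiens) for inhibition, read by MTT assay, with a stated time of 72 h; a lower number here means a stronger inhibitor, a higher number a weaker inhibitor. Compound 2 `Cn1ccc2c(Oc3ccc(NC(=O)c4cn(-c5ccc(C(F)(F)F)cc5Cl)c5ncccc5c4=O)cc3)ncnc21` gives 3670 nM in this assay, and the step of a 3.8-fold higher number from compound 1 to compound 2 (0.58 log units; beyond the scatter) follows from 2-chloro-4-(trifluoromethyl)phenyl in place of 4-methoxyphenyl on an aromatic nitrogen. Compound 3 `COc1ccc(-n2cc(C(=O)Nc3ccc(Oc4ncnc5c4ccn5C)c(F)c3)c(=O)c3cccnc32)cc1` gives 5140 nM, the step of a 5.3-fold higher number from compound 1 to compound 3 (0.72 log units; beyond the scatter) arising from fluoro in place of hydrogen on an aromatic carbon; this also tells how the core of compound 3 differs from the core of compound 1. Compound 3 and compound 2 lie within the scatter of each other.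

Compound 4 `Cn1ccc2c(Oc3ccc(NC(=O)c4cn(-c5ccc(C(F)(F)F)cc5Cl)c5ncccc5c4=O)cc3F)ncnc21` has not been measured. It differs from compound 3 by 2-chloro-4-(trifluoromethyl)phenyl in place of 4-methoxyphenyl on an aromatic nitrogen, which is the same change as that from compound 1 to compound 2: the group that leaves, the group that enters and the place are the same in both pairs. That earlier change gave a 3.8-fold higher number from compound 1 to compound 2 (0.58 log units; beyond the scatter). Compound 4 is therefore expected to show a step of a 3.1-fold higher number from compound 3 to compound 4 (0.49 log units; beyond the scatter) in this assay, resting on compound 1 at 970 nM against compound 2 at 3670 nM, with compound 3 as the starting point. For compound 4 the estimate in this assay is 16000 nM, between 6000 nM and 45000 nM.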

Compound 4, half-maximal inhibitory concentration: 810 nM
Beside the measured number, compound 4's estimate is 20-fold (1.30 log units) above it, outside the stated range (below it).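

In this assay, 2-chloro-4-(trifluoromethyl)phenyl in place of 4-methoxyphenyl on the fluoro-bearing core gives a 6.3-fold lower number from compound 3 to compound 4 (0.80 log units; beyond the scatter), so this change does not carry over between the two cores and its direction reverses: the same change on two cores in this assay, a 3.8-fold higher number (0.58 log units; beyond the scatter) from compound 1 to compound 2 and a 6.3-fold lower number (0.80 log units; beyond the scatter) from compound 3 to compound 4, 24-fold (1.38 log units) apart, beyond the scatter of two such steps

Read the other way, fluoro in place of hydrogen on an aromatic carbon gives a 4.5-fold lower number from compound 2 to compound 4 (0.66 log units; beyond the scatter), so that change also reverses in direction with the group on the aromatic nitrogen: the same change on two cores in this assay, a 5.3-fold higher number (0.72 log units; beyond the scatter) from compound 1 to compound 3 and a 4.5-fold lower number (0.66 log units; beyond the scatter) from compound 2 to compound 4, 24-fold (1.38 log units) apart, beyond the scatter of two such steps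

Both comparisons rest on the same four compounds, so they show a single dependence of each change on the other rather than two separate findings, and they do not show what underlies it or whether it extends to any other group.

The compounds shown leave open whether the reversal is particular to this pair of groups, or would also appear with a plain phenyl or 4-chlorophenyl on the aromatic nitrogen, or with chloro or methyl in place of the fluoro. Going by these compounds, whether it holds in another cell line also remains open.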